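This account rests on a few compounds, and the source may have more. Where it says the series, first, only, none or still open, it means among the compounds named here.

Measured so far in an ADME assay on microsomes from liver (Mus musculus) for metabolic stability; a higher number here means that the compound lasts longer, a lower number that the compound disappears faster:
- compound 1 `CC(C)C(Nc1nccs1)c1ccc(-c2ccc3cccc(F)c3c2)[nH]c1=O`: 0.0733 h
- compound 2 `CC(C)C(c1noc(=O)[nH]1)c1ccc(-c2ccc3cccc(F)c3c2)[nH]c1=O`: > 3 h, a limit of the assay and not a number

Compound 2 therefore has no exact half-life, and its reading is the limit of > 3 h in this assay, at which 1 of the 2 values shown sits.

The next change leads to compound 3 `Cc1c[nH]c(C(c2ccc(-c3ccc4cccc(F)c4c3)[nH]c2=O)C(C)C)n1`: a group of 6 heavy atoms (4 carbon, 2 nitrogen; one five-membered aromatic ring with 2 hetero atoms) in place of a group of 6 heavy atoms (2 carbon, 2 nitrogen, 2 oxygen; one five-membered aromatic ring with 3 hetero atoms), on a saturated chain carbon bound to an aromatic carbon and a saturated chain carbon. For the measured compounds named here, the 4-methyl-1H-imidazol-2-yl group enters on a saturated chain carbon bound to an aromatic carbon and a saturated chain carbon, the place where the only measured step also occurred. That step, an at least 40-fold higher number from compound 1 to compound 2 (1.61 log units; beyond the scatter), was large and beyond the scatter. It is a single step, so the ground for any forecast is thin. Like compound 1 at 0.0733 h, compound 3 carries a five-membered aromatic ring with 2 hetero atoms there, although its group has 4 carbon and 2 nitrogen atoms and no sulfur. The expectation is thus a large fall towards compound 1, probably not all the way: the expected change is an at least 10-fold lower number from compound 2 to compound 3 (1.00 log units; beyond the scatter). In this assay the estimate for compound 3 is 0.3 h, with an expected range of 0.07 h to 1.5 h.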

Compound 3, half-life: < 0.0667 h
Compound 3: a limit, no number; the forecaster's own chance of this, stated with the estimate: 8%; middle value at least 4.4-fold (0.65 log units) away from the limit.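

In this assay, putting the 4-methyl-1H-imidazol-2-yl group on the saturated chain carbon gives an at least 44-fold lower number from compound 2 to compound 3 (1.65 log units; beyond the scatter), so the large swing at this place does not depend on the (1,3-thiazol-2-yl)amino group alone, and a second group, one without sulfur, also sits at the short-lived end. Compound 3 gives a limit of the assay and not a number: the limit of < 0.0667 h in this assay, at which 1 of the 3 values shown sits. The step on the other side reads an at least 1.0-fold lower number from compound 1 to compound 3 (0.04 log units; that floor lies within the scatter), a floor that allows no order between the two, and of the three groups shown at this place only the one with 3 hetero atoms in its five-membered aromatic ring goes with the long half-life.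

The compounds shown leave open whether that long half-life follows the ring as a whole or its carbonyl, a question that a carboxylic acid on the same saturated chain carbon would help to separate. As far as these compounds go, both ends of the range are limits, so the full size of the swing at this place also stays open.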